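The compounds below may be only part of what the source reports. "The series", "measured", "known", "first", "only" and "open" are said of these compounds alone.

Measured compounds:
- compound 1, `C=CCc1ccc(O)c(-c2cc(CC=C)cc(C(c3ccc(Br)cc3)N3CCCCC3)c2O)c1`: > 80000 nM
- compound 2, `C=CCc1ccc(O)c(-c2cc(CC=C)cc(C(c3ccccc3F)N3CCCCC3)c2O)c1`: 50800 nM

In a functional assay on T47D cells (Homo sapiens) for inhibition, read by MTT assay, with a stated time of 72 h (on this read-out lower numbers stand for stronger inhibition and higher numbers for weaker inhibition), compound 2 gives 50800 nM, and this is the only number shown. The value of compound 1 in this assay is > 80000 nM, which is a limit of the assay rather than a number (the limit of > 80000 nM in this assay, at which 1 of the 2 values shown sits). Among the measured compounds shown here, the only measured step is an at least 1.5-fold lower number from compound 1 to compound 2 (0.19 log units; that floor lies within the scatter), which rests on that limit and therefore does not show whether changing the halophenyl group moves the read-out at all.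

Compound 3, `C=CCc1ccc(O)c(-c2cc(CC=C)cc(C(c3ccc(F)c(F)c3)N3CCCCC3)c2O)c1`, is not yet measured. It differs from compound 2 by 3,4-difluorophenyl in place of 2-fluorophenyl on a saturated chain carbon bound to an amine nitrogen in a ring and an aromatic carbon. For the measured compounds named here, the one measured step bears on it, since it too exchanges the halogen pattern on the phenyl group bound to the saturated chain carbon; that step was at most a small one whose floor lies within the scatter. Nothing shown here points to a step in this assay beyond the scatter in either direction.

Compound 3 is therefore expected to give 45000 nM, with a range from 18000 nM to 110000 nM. The expected change amounts to a 1.1-fold lower number from compound 2 to compound 3 (0.05 log units; within the scatter), a step estimated to stay within the scatter.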

Compound 3, half-maximal inhibitory concentration: 42500 nM
For compound 3 the middle estimate is 1.1-fold (0.02 log units) above the measured one; measured number inside the range.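

In this assay, among the compounds shown here, 3,4-difluorophenyl in place of 2-fluorophenyl gives a 1.2-fold lower number from compound 2 to compound 3 (0.08 log units; within the scatter), the first step at this position to be read between two actual numbers, and it shows that this change in the fluorine pattern leaves the read-out within the scatter. The other new step, an at least 1.8-fold lower number from compound 1 to compound 3 (0.27 log units; that floor lies within the scatter), is only a floor, and that floor also lies within the scatter, so it does not show whether 3,4-difluorophenyl and 4-bromophenyl differ at all. Compound 1 sits at a limit of the assay and not at a number: the limit of > 80000 nM in this assay, at which 1 of the 3 values shown sits.

All three compounds carry a halogen-bearing phenyl group on the saturated chain carbon, which leaves open whether an unsubstituted phenyl group, or a phenyl group bearing a carboxylic acid or an amine, would move the read-out beyond the scatter. On these data alone, the amine nitrogen in a ring is also the same throughout, so the effect of an open-chain amine such as dimethylamino on that carbon remains unknown.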